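The source may report more compounds than this note shows. Statements on the series, on what has been measured and on what is new or still open speak of the compounds shown alone.

Measured so far in a physicochemical assay for lipophilicity, using the shake flask method, in phosphate buffer, measured as octanol-water partition, with a stated time of 30 min, at pH 7.4; on this read-out higher numbers stand for higher lipophilicity and lower numbers for lower lipophilicity:
- compound 1, `O=C1c2ccccc2CN1c1cnc(NCc2c(F)ccc3c2CCO3)n2cnnc12`: 2.7
- compound 2, `Cc1nc(CO)ccc1-c1cnc(NCc2c(F)ccc3c2CCO3)c2cn[nH]c(=O)c12`: 2.4
- compound 3, `Cc1ncccc1-c1cnc(NCc2c(F)ccc3c2CCO3)c2ncc(=O)[nH]c12`: 2.8

Compound 1 stands second of the three in this assay; compound 3 is nearest, and compound 2 is furthest, both within the usual scatter, so the three numbers are not separable.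

The next compound is compound 4, `CN(c1cccnc1)c1cnc(NCc2c(F)ccc3c2CCO3)n2cnnc12`. Relative to compound 1 the change is a group of 8 heavy atoms (6 carbon, 2 nitrogen; one six-membered aromatic ring with 1 hetero atom) in place of a group of 10 heavy atoms (8 carbon, 1 nitrogen, 1 oxygen; one five-membered non-aromatic ring with 1 hetero atom, one six-membered aromatic ring of carbon only), on an aromatic carbon. Among the compounds with values here, no measured pair in the set shows a step of this kind, so nothing in the data fixes its size; the methyl(pyridin-3-yl)amino group is expected to leave the number close to that of compound 1, with at most a small step downward, not clearly beyond the scatter: a number 0.20 log units lower from compound 1 to compound 4 (within the scatter). Compound 4 is thus estimated at 2.5, range 2 to 3.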

Compound 4, distribution coefficient: 2.6
Compound 4: the middle estimate sits 0.10 log units below what was measured, and the stated range covers the measured number.
By their numbers in this assay, from the lowest: compounds 2, 4, 1 and 3 (each within the scatter of the next, the first and the last beyond it).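

In this assay, methyl(pyridin-3-yl)amino in place of the two-ring group on this aromatic carbon gives a number 0.10 log units lower from compound 1 to compound 4 (within the scatter), the first step read at this position. A single six-membered aromatic ring with 1 hetero atom can therefore replace a five-membered non-aromatic ring plus a carbon-only aromatic ring here without a step beyond the scatter. No measurement available explains this step.

As far as these compounds go, whether a carboxylic acid or a primary amine on this carbon would give a step beyond the scatter remains open. From the compounds shown here alone, the separate contributions of the methyl and the pyridine ring nitrogen also remain open.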